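Carbamate and urea pair with aryl swap

A few compounds are considered here, and "the series" means these few. Any claim that something is new, unique, unknown or untested is made for them only; others in the source may bear on it.

Measured in an assay on NIH3T3 cells with Urotensin-2 receptor (Homo sapiens) as the target; on this read-out lower numbers stand for smaller maximal responses and higher numbers for larger maximal responses:
compound 1 `Cc1ccccc1NC(=O)OC(CCN(C)C)c1ccc(Cl)cc1` gives 176%
compound 2 `COc1ccc(NC(=O)OC(CCN(C)C)c2ccc(Cl)cc2)cc1` gives 170%
compound 3 `Cc1ccccc1NC(=O)NC(CCN(C)C)c1ccc(Cl)cc1` gives 175%

Compound 1 and compound 2 differ by one change, (4-methoxyphenyl in place of 2-methylphenyl on an amide-type nitrogen). The step of a number 6 percentage points lower from compound 1 to compound 2 (within the scatter) is small, and all three measured values in this assay lie within the scatter of one another, so no order among them is claimed. Compound 3 and compound 1 differ in more than one place; the difference between the two cores is not broken down here.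

Compound 4 `COc1ccc(NC(=O)NC(CCN(C)C)c2ccc(Cl)cc2)cc1` has not been measured in this assay. Relative to compound 3 it carries 4-methoxyphenyl in place of 2-methylphenyl on an amide-type nitrogen, the same change, at the same place, as the one from compound 1 to compound 2. Going by the values given here, only this single measured pair is available to judge it. Because that pair gave a number 6 percentage points lower from compound 1 to compound 2 (within the scatter), a step of similar size is expected, a number 6 percentage points lower from compound 3 to compound 4 (within the scatter). Compound 4 is therefore estimated in this assay at 169%, with the expected range from 155% to 183%.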

Compound 4, largest response reached (reported as efficacy), in percent of the reference or control that the assay uses: 195%
Compound 4: middle estimate off by 26 percentage points, on the low side; measured number above the stated range.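

In this assay, 4-methoxyphenyl in place of 2-methylphenyl on the amide-type nitrogen gives a number 20 percentage points higher from compound 3 to compound 4 (beyond the scatter), so on this core the change has a measurable effect on maximal response. Set beside the same change on the core of compound 1, the result does not transfer as a constant step between these cores: the same change on two cores in this assay, a number 6 percentage points lower (within the scatter) from compound 1 to compound 2 and a number 20 percentage points higher (beyond the scatter) from compound 3 to compound 4, 26 percentage points apart, beyond the scatter of two such steps

Going by these compounds alone, this rests on a single pair per core, so it shows only that a step read on one core cannot be assumed to hold on the other, not how the change behaves in general or what underlies the difference.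

From the compounds shown here alone, whether the split between the cores also appears with other groups on that nitrogen, such as unsubstituted phenyl or a pyridine ring, remains open. Also open, going by these compounds, is whether it survives when the dimethylamino group gives way to a primary amine or the chain carrying it is made longer.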